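The source may report more compounds than this note shows. Statements on the series, on what has been measured and on what is new or still open speak of the compounds shown alone.

Measured in an ADME assay on NIH3T3 cells (Mus musculus) for inhibition, read by MTT assay, with a stated time of 48 h; on this read-out higher numbers stand for weaker inhibition and lower numbers for stronger inhibition:
Compound 1 `CCc1ccc(-c2nc3ccccn3c2Sc2ccccc2)cc1`: > 100000 nM, a limit
Compound 2 `CSc1ccc(-c2nc3ccccn3c2Sc2ccccc2)cc1`: > 100000 nM, a limit

Neither entry is a number. Within the data shown here, compound 2 has only its limit of > 100000 nM to place it, and the one other value shown, that of compound 1, is also a limit. Among the measured compounds shown here, the single measured step is a step that the two limits leave unreadable from compound 1 to compound 2, with methylsulfanyl in place of ethyl on an aromatic carbon. It therefore supplies no size that could be carried forward.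

Compound 3 `c1ccc(Sc2c(-c3cccs3)nc3ccccn23)cc1` departs from compound 2 at a different place: thiophen-2-yl in place of 4-(methylsulfanyl)phenyl on an aromatic carbon. Here thiophen-2-yl stands in place of 4-(methylsulfanyl)phenyl on an aromatic carbon, next to the ring atom that bears a phenylsulfanyl group.

For the measured compounds named here, no measured step covers this change, so no particular size or direction of change is expected in this assay. Going by the values given here, the only guide for compound 3 is the limit of > 100000 nM in this assay, at which 2 of the 2 values shown sit, and it is expected to stay close to that limit. The expected step is a number no higher from compound 2 to compound 3 (the limit leaves the size open). The estimate for compound 3 is 100000 nM, with an expected range from 30000 nM to 300000 nM.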

Compound 3, half-maximal inhibitory concentration: > 100000 nM
Compound 3 gave a limit, no number; the forecaster's own chance of this, stated with the estimate: 75%; the middle value sits exactly at the limit.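

In this assay, among these compounds, compound 3 gave a limit and not a number, so no step among compound 1, compound 2 and compound 3 can be read: the limit of > 100000 nM in this assay, at which 3 of the 3 values shown sit.

The compounds shown leave open whether exchanging 4-ethylphenyl, 4-(methylsulfanyl)phenyl and thiophen-2-yl changes inhibition of these cells at all, and at what concentration any of the three would reach half-maximal inhibition.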